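The source may hold more compounds than are shown below. What is called first, only, known or untested is meant among the compounds shown, and "the series" means these compounds.

Measured set:
compound 1 `O=C(/C=C/c1cccc(NC(=O)c2ccccc2Br)c1)c1nc2ccccc2[nH]1` — 1680 nM
compound 2 `O=C(Nc1cccc(/C=C/C(=O)c2nc3ccccc3[nH]2)c1)c1cccc(Br)c1` — 1560 nM
compound 3 `Cc1ccc(C(=O)Nc2cccc(/C=C/C(=O)c3nc4ccccc4[nH]3)c2)cc1` — 1660 nM

All three values come from a functional assay on HCT-116 cells (Homo sapiens) for antiproliferative activity, read by MTT assay, with a stated time of 48 h; a higher number here means a weaker inhibitor, a lower number a stronger inhibitor. Compound 3 sits second highest of the three numbers, but every step among them stays within the scatter: a 1.1-fold lower number from compound 1 to compound 2 (0.03 log units; within the scatter), a 1.0-fold lower number from compound 1 to compound 3 (0.01 log units; within the scatter), a 1.1-fold higher number from compound 2 to compound 3 (0.03 log units; within the scatter). Compound 4 `Cc1ccccc1S(=O)(=O)Nc1cccc(/C=C/C(=O)c2nc3ccccc3[nH]2)c1` introduces ((2-methylphenyl)sulfonyl in place of (4-methylphenyl)carbonyl on a nitrogen on an aromatic ring). Going by the values given here, the measured steps only swap the aryl group on the carbonyl, and none of them moved this assay beyond the scatter; no step touches the carbonyl itself, so the carbonyl-to-sulfonyl exchange is uncovered. The expectation is therefore no movement beyond the scatter, with widened uncertainty: compound 4 is estimated at 1700 nM (range 700 nM to 4500 nM), a step of a 1.0-fold higher number from compound 3 to compound 4 (0.01 log units; within the scatter).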

Compound 4, half-maximal inhibitory concentration: 955 nM
Estimate against measurement, compound 4: 1.8-fold (0.25 log units) above; the range from low to high includes it.
By their numbers in this assay, from the lowest: compounds 4, 2, 3 and 1 (each within the scatter of the next).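

Working notes: the nitrogen on the aromatic ring accepts (2-methylphenyl)sulfonyl in this assay with a 1.7-fold lower number from compound 3 to compound 4 (0.24 log units; within the scatter) and with a 1.6-fold lower number from compound 2 to compound 4 (0.21 log units; within the scatter) and also with a 1.8-fold lower number from compound 1 to compound 4 (0.25 log units; within the scatter) in the same reading. The earlier steps shown here only swapped the aryl group on the carbonyl, whereas these replace the carbonyl itself and still stay within the scatter. Nothing available explains this result.

Going by these compounds, the sulfonyl exchange and the shifted methyl arrive together, so their separate contributions remain open. Also open, on these data alone, is how a methylsulfonyl or an acetyl group on that nitrogen would read.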